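The compounds below may be only part of what the source reports. "The series", "measured", "known", "first", "only" and "open" are said of these compounds alone.

Measured so far:
compound 1, `Nc1ccc2cccc(OCCC3CC3)c2n1`: 492 nM
compound 2, `Nc1ccc2cccc(OCC3CCC3)c2n1`: 432 nM

Both were tested in an assay on cells with melanin-concentrating hormone receptor 1 (Homo sapiens) as the target, read by radioligand binding; a lower number here means a stronger inhibitor, a higher number a weaker inhibitor. On those two numbers compound 2 sits at the end with the smaller value, yet the step of a 1.1-fold lower number from compound 1 to compound 2 (0.06 log units; within the scatter) lies within the scatter, so the two compounds cannot be told apart. Compound 3, `CCOCC(C)Oc1cccc2ccc(N)nc12`, has not yet been tested. It differs from compound 2 by a group of 6 heavy atoms (5 carbon, 1 oxygen; no ring) in place of a group of 5 heavy atoms (5 carbon; one four-membered non-aromatic ring of carbon only), on an oxygen on an aromatic ring. Within the data shown here, only one measured step bears on this position, a 1.1-fold lower number from compound 1 to compound 2 (0.06 log units; within the scatter), and it was within the scatter; it swapped one small ring for another, whereas here a ring gives way to a chain carrying an oxygen, so that step gives little guidance on direction. For compound 3 the expected step is therefore a 1.4-fold higher number from compound 2 to compound 3 (0.14 log units; within the scatter), a modest one with a wide range in either direction. Compound 3 is estimated at 600 nM, with a range from 200 nM to 1800 nM.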

Compound 3, half-maximal inhibitory concentration: 1070 nM
Compound 3: middle estimate off by 1.8-fold (0.25 log units), on the low side; measured number inside the range.
By their numbers in this assay, from the lowest: compounds 2 and 1 (each within the scatter of the next); then compound 3.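

In this assay, the group on the oxygen on an aromatic ring now makes a difference beyond the scatter: trading a carbon ring for the open chain carrying an oxygen gives a 2.5-fold higher number from compound 2 to compound 3 (0.39 log units; beyond the scatter) and also a 2.2-fold higher number from compound 1 to compound 3 (0.34 log units; beyond the scatter) as a second modest step. The position therefore does not accept every group of this size equally, even though the two ring-bearing groups could not be told apart. Nothing available explains the rise in the number.

The ring is lost and an oxygen is gained in the same change, so the compounds shown do not reveal which of the two matters. On these data alone, a pentyl chain, open like the new group but made of carbon only, would separate these two changes, and an amine on the chain remains untested here as well.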